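The source may hold more compounds than are shown below. What is called first, only, known or untested is meant among the compounds shown, and "the series" means these compounds.

Measured compounds in an assay on isolated protein for inhibition of Nicotinamide phosphoribosyltransferase (Homo sapiens), read by mass spectrometry, with stated times of 15 min and 30 min; a lower number here means a stronger inhibitor, a higher number a weaker inhibitor:
- compound 1, `O=S(=O)(c1ccccc1)c1ccc(CNS(=O)(=O)N2Cc3ccncc3C2)cc1`: > 2000 nM
- compound 2, `O=C(NCc1ccc(S(=O)(=O)c2cc(F)cc(F)c2)cc1)N1Cc2ccncc2C1`: 7.1 nM

Compound 1 returns only a limit in this assay, (the limit of > 2000 nM in this assay, at which 1 of the 2 values shown sits), so no number is available for it. For the measured compounds named here, compound 2 gives the only numeric value shown in this assay, 7.1 nM. Going by the values given here, no step between two measured compounds can be drawn here.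

Compound 3, `O=C(NCc1ccc(S(=O)(=O)C2CCC(F)(F)CC2)cc1)N1Cc2ccncc2C1`, differs from compound 2 in one place: 4,4-difluorocyclohexyl in place of 3,5-difluorophenyl on a sulfonyl sulfur. Among the compounds with values here, with no measured step to lean on, the expected shift from compound 2 to compound 3 in this assay is a moderate loss, a 3.5-fold higher number from compound 2 to compound 3 (0.55 log units; beyond the scatter), beyond the usual scatter but not large. For compound 3 the estimate in this assay is 25 nM, within 5 nM to 120 nM.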

Compound 3, half-maximal inhibitory concentration: 78 nM
Beside the measured number, compound 3's estimate is 3.1-fold (0.49 log units) below it; measured number inside the range.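

In this assay, for the compounds shown here, the change on the sulfonyl sulfur gives an 11-fold higher number from compound 2 to compound 3 (1.04 log units; beyond the scatter) and is the first measured step. The aromatic 3,5-difluorophenyl and the non-aromatic 4,4-difluorocyclohexyl have the same heavy-atom count yet are not interchangeable at this position, though compound 3 still gives a number and not a limit.

From the compounds shown here alone, whether a pyridine ring or a morpholine on the sulfonyl sulfur would hold the value of compound 2 stays open. Nothing measured here accounts for the size of this step.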